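The source may hold more compounds than are shown below. What is called first, only, known or untested is meant among the compounds shown, and "the series" means these compounds.

Of the compounds shown here, three built on one shared core have been tested in a functional assay on the whole organism with Mus musculus as the target; on this read-out higher numbers stand for an effect only at larger amounts of compound and lower numbers for an effect already at smaller amounts. Compound 1 `CC(C)NCc1nnc(-c2ccccc2-c2ccccc2)s1` gives 23 mg/kg. Compound 3 `CN(C)Cc1nnc(-c2ccccc2-c2ccccc2)s1` gives 32 mg/kg in this assay. Compound 2 `Cc1ccccc1NCc1nnc(-c2ccccc2-c2ccccc2)s1` reaches only a limit of the assay, > 200 mg/kg, so no number is known for it. Compound 2 thus sits at the limit of > 200 mg/kg in this assay, at which 1 of the 3 values shown sits. Of the two numbers, compound 3 and compound 1 lie within the usual scatter of each other, as the step of a 1.4-fold higher number from compound 1 to compound 3 (0.14 log units; within the scatter) shows, so neither can be called stronger or weaker. The steps of an at least 8.6-fold higher number from compound 1 to compound 2 (0.93 log units; beyond the scatter) and an at least 6.2-fold lower number from compound 2 to compound 3 (0.79 log units; beyond the scatter) are clearly larger, and both involve the 2-methylphenyl group carried only by compound 2.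

Compound 4 `CNCc1nnc(-c2ccccc2-c2ccccc2)s1` differs from compound 3 by hydrogen in place of methyl on an amine nitrogen, the nitrogen concerned having a saturated chain carbon and a saturated chain carbon as its other neighbours. The step most like this one is a 1.4-fold higher number from compound 1 to compound 3 (0.14 log units; within the scatter), which also exchanged small saturated groups on that amine and stayed within the scatter; the 2-methylphenyl group behind the large steps plays no part here. Compound 4 is therefore expected to show a step of a 1.1-fold lower number from compound 3 to compound 4 (0.03 log units; within the scatter), within the scatter. Compound 4 is estimated at 30 mg/kg, with a range from 12 mg/kg to 80 mg/kg.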

Compound 4, dose for half-maximal effect: 25 mg/kg
Beside the measured number, compound 4's estimate is 1.2-fold (0.08 log units) above it; low and high end bracket the measured number.
By their numbers in this assay, from the lowest: compounds 1, 4 and 3 (each within the scatter of the next). At a limit, above all of these: compound 2.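

The exchange of methyl for hydrogen on this amine nitrogen gives a 1.3-fold lower number from compound 3 to compound 4 (0.11 log units; within the scatter), so the dimethylamino and methylamino forms cannot be told apart in this assay. Replacing the isopropyl group of compound 1 with methyl likewise gives only a 1.1-fold higher number from compound 1 to compound 4 (0.04 log units; within the scatter), so compound 1, compound 3 and compound 4 form a set of small saturated amines whose numbers lie within the scatter of one another, and neither the size of the saturated group nor the presence of a hydrogen on the nitrogen separates them. The 2-methylphenyl group of compound 2 goes against this pattern, with an at least 8.0-fold lower number from compound 2 to compound 4 (0.90 log units; beyond the scatter), and that step starts from a limit of the assay and not from a number: the limit of > 200 mg/kg in this assay, at which 1 of the 4 values shown sits.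

On these data alone, it remains open whether an unsubstituted phenyl group on this nitrogen would behave like the 2-methylphenyl group or like the small saturated groups, and the same question applies to a benzyl group or a longer chain such as butyl. As far as these compounds go, the primary amine, with hydrogen in place of the last methyl, and a cyclic amine such as piperidine also remain open.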